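The source may hold more compounds than are shown below. What is called first, only, known or untested is meant among the compounds shown, and "the series" means these compounds.

Compound 1, `O=C(OC[C@H]1O[C@@H](O[C@@H](C(=O)O)c2ccccc2)[C@H](O)[C@@H](O)[C@@H]1O)c1ccccc1`, is known in an ADME assay on HCT-8 cells (Homo sapiens) for cytotoxicity (on this read-out lower numbers stand for stronger inhibition and higher numbers for weaker inhibition), only as a limit of the assay, where compound 1 gives > 10000 nM. Two related glycosides share this position. Compound 2, `O=C(OC[C@H]1O[C@@H](OC[C@H]2O[C@@H](OCc3ccccc3)[C@H](O)[C@@H](O)[C@@H]2O)[C@H](O)[C@@H](O)[C@@H]1O)c1ccccc1`, gives in this assay a limit of > 10000 nM. Compound 3, `O=C(OC[C@H]1O[C@@H](OC[C@H]2O[C@@H](OC(=O)c3ccccc3)[C@H](O)[C@@H](O)[C@@H]2O)[C@H](O)[C@@H](O)[C@@H]1O)c1ccccc1`, likewise gives in this assay a limit of > 10000 nM. Within the data shown here, the single step between measured compounds that differ in one place, a step that the two limits leave unreadable from compound 2 to compound 3, puts benzoyl in place of benzyl on an oxygen on a saturated carbon and cannot be read, because of the limit of > 10000 nM in this assay, at which 3 of the 3 values shown sit. Compound 4, `COc1cc(CO)ccc1O[C@@H]1O[C@H](COC(=O)c2ccccc2)[C@@H](O)[C@H](O)[C@H]1O`, differs from compound 1 by 4-(hydroxymethyl)-2-methoxyphenyl in place of carboxy(phenyl)methyl on an oxygen on a saturated carbon. Among the measured compounds shown here, no measured step bears directly on this change, and every value seen so far sits at the same limit, so no step beyond the scatter in either direction can be expected for this assay. Compound 4 is therefore expected to give 20000 nM in this assay, within a range from 8000 nM to 100000 nM. The step from compound 1 to compound 4 is expected to be a step that the limit leaves unreadable from compound 1 to compound 4, most likely ending again at a limit rather than a number.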

Compound 4, half-maximal inhibitory concentration: > 10000 nM
Compound 4: no number, only a limit (the forecaster's own chance of this, stated with the estimate: 85%); the middle value does not contradict the limit.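

No step can be read from compound 1 to compound 4, because neither compound gives a number: the limit of > 10000 nM in this assay, at which 4 of the 4 values shown sit. The compounds shown leave open how they compare with one another in this assay, and whether any change on the shared core would give a number there.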